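Notes on the carbonyl arm of compound 1

The source may hold more compounds than are shown below. What is called first, only, known or untested is meant among the compounds shown, and "the series" means these compounds.

Compound 1 `COc1ccc(-c2csc(N)c2C(=O)OCc2ccccc2C)cc1OC` gives 64% in an assay on isolated protein for inhibition of protein kinase C zeta type (Homo sapiens), with stated times of 1 h and 2.5 min, tested at 30 uM (on this read-out lower numbers stand for less inhibition and higher numbers for more inhibition at the one concentration tested (going by the name of the read-out)), the highest of the two numbers in hand. Within the data shown here, the only other measured member, compound 2 `COc1ccc(-c2csc(N)c2C(=O)OCc2ccc(C#N)cc2)cc1OC`, gives 10% in this assay; the step of a number 54 percentage points lower from compound 1 to compound 2 (beyond the scatter) comes from 4-cyanophenyl in place of 2-methylphenyl on a saturated chain carbon bound to an oxygen next to a carbonyl group, and it is large.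

Compound 3 `COCCNC(=O)c1c(-c2ccc(OC)c(OC)c2)csc1N` has not been measured. It differs from compound 1 as follows: (2-methoxyethyl)amino in place of (2-methylbenzyl)oxy on a carbonyl carbon. Among the measured compounds shown here, the change sits on the carbonyl carbon whose other neighbour is aromatic carbon, so it works on the same arm that the one measured step varies, but that step exchanged one aryl group for another while keeping the oxygen-linked benzylic arm. For the measured compounds named here, no measured pair exchanges an oxygen-linked arm for a nitrogen-linked one or removes the ring; the step of a number 54 percentage points lower from compound 1 to compound 2 (beyond the scatter) bears on compound 3 only in showing that changing this arm can move the number a great deal. A downward step, probably beyond the scatter, is therefore expected, with a wide range given the lack of a close analogue. Compound 3 is estimated at 25%, between 0% and 60%, which means an expected step of a number 39 percentage points lower from compound 1 to compound 3 (beyond the scatter).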

Compound 3, a percentage reported as inhibition, at one concentration (the size of the read-out at that concentration, not a potency): 55%
The estimate for compound 3 lay 30 percentage points below the measured number, within the range that was stated.
By their numbers in this assay, from the lowest: compound 2; then compounds 3 and 1 (each within the scatter of the next).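

On the carbonyl carbon, (2-methoxyethyl)amino in place of (2-methylbenzyl)oxy gives a number 9 percentage points lower from compound 1 to compound 3 (within the scatter) in this assay, so within these compounds neither the oxygen link nor the six-membered aromatic ring of carbon only is needed at this place to keep a number of this size. Among these compounds, the one earlier step, a number 54 percentage points lower from compound 1 to compound 2 (beyond the scatter), showed only that this arm can move the number a great deal, whereas the new result shows that the presence of a ring on the arm does not by itself set it: compound 1 at 64% and compound 2 at 10% both carry one, while compound 3 at 55% has none. Nothing in hand bears on why these arms behave as they do.

Open, on these data alone, is whether the nitrogen link or the 2-methoxyethyl chain accounts for the result with compound 3, a question that a (2-methylbenzyl)amino arm or a carboxylic acid on the same carbonyl carbon would help to separate. As far as these compounds go, since this assay reports one concentration only, it also remains open whether compound 1 and compound 3 would stay together across a range of concentrations.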